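The source may report more compounds than this note shows. Statements on the series, on what has been measured and on what is new or still open speak of the compounds shown alone.

Measured so far:
compound 1, `CCC(CC)(c1ccc(OCC(=O)O)c(C)c1)c1ccc(OCC(O)C(C)(C)C)c(OCC(O)C(C)(C)C)c1`, 10%
compound 2, `CCC(CC)(c1ccc(OCCCCCCC(=O)O)c(C)c1)c1ccc(OCC(O)C(C)(C)C)c(OCC(O)C(C)(C)C)c1`, "not active" (no number reported)

Two compounds share one core and differ only in the group carried on an oxygen on an aromatic ring. In an assay on cells for binding affinity to vitamin D3 receptor (Homo sapiens), read by fluorescence, tested at 1 uM (a higher number here means more inhibition at the concentration tested (going by the name of the read-out), a lower number less inhibition), compound 1 gives 10%. In this assay compound 2 was reported as "not active" (no number reported), so no single number stands for compound 2 and its distance from compound 1 cannot be counted. Compound 3, `CCC(CC)(c1ccc(OS(=O)(=O)c2ccc([N+](=O)[O-])cc2)c(C)c1)c1ccc(OCC(O)C(C)(C)C)c(OCC(O)C(C)(C)C)c1`, has not been measured. It differs from compound 2 in one place: (4-nitrophenyl)sulfonyl in place of 6-carboxyhexyl on an oxygen on an aromatic ring. Among the compounds with values here, no step between two measured compounds is known that would show how such a change moves the read-out; only the low level of compound 1 and the absence of a number for compound 2 are known. A step of no more than the usual scatter is therefore expected in this assay, in either direction. Compound 3 is estimated to give 12%, between 0% and 35%.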

Compound 3, a percentage reported as inhibition, at one concentration (the size of the read-out at that concentration, not a potency): 29%
For compound 3 the middle estimate is 17 percentage points below the measured one, within the range that was stated.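

In this assay, within the data shown here, (4-nitrophenyl)sulfonyl in place of carboxymethyl on an oxygen on an aromatic ring gives a number 19 percentage points higher from compound 1 to compound 3 (beyond the scatter) and is the one readable step showing that the group at this place can move the read-out beyond the scatter. It also shows that this oxygen can carry a group with no carboxylic acid and still give a measured number, while the step from compound 2 to compound 3 cannot be read, as compound 2 has no number. Nothing at hand bears on why this change moves the read-out.

As far as these compounds go, it remains open whether the nitro group or the sulfonyl link accounts for the step, and what a plain phenylsulfonyl or a methanesulfonyl on this oxygen would give. From the compounds shown here alone, how an amide-bearing chain at this place would read also remains open.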